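The source may report more compounds than this note shows. Statements on the series, on what has been measured and on what is new or still open speak of the compounds shown alone.

Three compounds share one core, and the structural differences among them sit at the aryl group carried by an oxygen on an aromatic ring and in the length of the connecting chain. Compound 1 `Cc1nn(C)c(Oc2cccc(F)c2)c1/C=N\CCCCCOc1cc2oc(=O)cc(C)c2cc1Cl` gives 11800 nM in a functional assay on SMMC-7721 cells (Homo sapiens) for antiproliferative activity, read by MTT assay, with a stated time of 72 h; on this read-out lower numbers stand for stronger inhibition and higher numbers for weaker inhibition. Compound 2 `Cc1nn(C)c(Oc2ccc(Cl)cc2)c1/C=N\CCCCCOc1cc2oc(=O)cc(C)c2cc1Cl` gives 17500 nM in this assay, and the change from compound 1 to compound 2 amounts to a 1.5-fold higher number from compound 1 to compound 2 (0.17 log units; within the scatter). Compound 3 `Cc1nn(C)c(Oc2cccc(F)c2)c1/C=N\CCCCCCOc1cc2oc(=O)cc(C)c2cc1Cl` gives 23600 nM in this assay; its number differs from those of compound 1 and compound 2 by no more than the usual scatter, so the three compounds cannot be told apart on these data.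

Compound 4 `Cc1nn(C)c(Oc2ccc(F)cc2F)c1/C=N\CCCCCCOc1cc2oc(=O)cc(C)c2cc1Cl` is not yet measured. It differs from compound 3 by 2,4-difluorophenyl in place of 3-fluorophenyl on an oxygen on an aromatic ring. Within the data shown here, the only measured step that touches the same place is the one from compound 1 to compound 2, which stayed within the scatter. Among the measured compounds shown here, no measured step bears on the second fluorine that enters here. A step within the scatter is therefore expected for this assay, in no particular direction. The estimate for compound 4 in this assay is 20000 nM, ranging from 8000 nM to 50000 nM, which means an expected step of a 1.2-fold lower number from compound 3 to compound 4 (0.07 log units; within the scatter).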

Compound 4, half-maximal inhibitory concentration: > 25000 nM
Compound 4: no number, only a limit; the forecaster's own chance of this, stated with the estimate: 10%; middle value at least 1.2-fold (0.09 log units) from the limit.
By their numbers in this assay, from the lowest: compounds 1, 2 and 3 (each within the scatter of the next). At a limit, above all of these: compound 4.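

In this assay compound 4 gives > 25000 nM, which is a limit of the assay and not a number. Read as a step, 2,4-difluorophenyl in place of 3-fluorophenyl on the oxygen gives an at least 1.0-fold higher number from compound 3 to compound 4 (0.02 log units; that floor lies within the scatter), so this change yields only a floor, whereas the earlier change at the same place had a measured size, a 1.5-fold higher number from compound 1 to compound 2 (0.17 log units; within the scatter). Compound 4 is the only compound shown that reaches such a limit, and the true size of its step therefore stays unknown, whether within the scatter or beyond it: the limit of > 25000 nM in this assay, at which 1 of the 4 values shown sits.

The compounds shown do not separate the entry of the second fluorine from the shift in the fluorine pattern, and they do not show whether 2,4-difluorophenyl would behave in the same way on the chain of compound 1. As far as these compounds go, it also remains open how this position would respond to a plain phenyl, or to an aryl group carrying a methoxy group, an amine or a carboxylic acid, and whether any such group would give a reading clearly apart from those of compound 1, compound 2 and compound 3.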